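The source may report more compounds than this note shows. Statements on the series, on what has been measured and on what is new or still open speak of the compounds shown alone.

Compound 1 `C=C(c1ccc(OC)cc1NC(=O)CO)c1ccc(OC)c2c1C=CC(C)(C)O2` — 280 nM
Compound 2 `C=C(c1ccc2c(c1)C=CC(C)(C)O2)c1ccc(OC)cc1NC(=O)CO` — 110 nM
Compound 3 `C=C(c1ccc(OC)cc1NC(=O)CN)c1ccc(OC)c2c1C=CC(C)(C)O2` — 400 nM

Of the compounds shown here, three have been measured in a functional assay on A2780 cells (Homo sapiens) for antiproliferative activity, read by MTT assay, with a stated time of 48 h; a higher number here means a weaker inhibitor, a lower number a stronger inhibitor. Compound 1 gives 280 nM, and compound 3, which carries the change (amino in place of hydroxy on a saturated chain carbon bound to a carbonyl carbon), gives 400 nM; the step of a 1.4-fold higher number from compound 1 to compound 3 (0.15 log units; within the scatter) is within the scatter of this assay, so the two values cannot be told apart. Compound 2 gives 110 nM, the lowest of the three numbers, and its steps to compound 1 and to compound 3 both lie beyond the scatter. Compound 2 and compound 1 differ in more than one place; the difference between the two cores is not broken down here.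

Compound 4 `C=C(c1ccc2c(c1)C=CC(C)(C)O2)c1ccc(OC)cc1NC(=O)CN` has not yet been measured. Among the measured compounds shown here, it stands to compound 2 as compound 3 stands to compound 1: the change amino in place of hydroxy on a saturated chain carbon bound to a carbonyl carbon is the same change, at the same place, as the one made from compound 1 to compound 3. Since that earlier step stayed within the scatter, the expectation for compound 4 rests on a step of about the same small size on the core of compound 2, which is the more potent of the two cores. Compound 4 is therefore expected to give 150 nM in this assay, with a likely range from 70 nM to 330 nM. The step this estimate means is a 1.4-fold higher number from compound 2 to compound 4 (0.13 log units; within the scatter), expected to remain within the scatter as the earlier one did, because a 1.4-fold higher number from compound 1 to compound 3 (0.15 log units; within the scatter) was itself small.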

Compound 4, half-maximal inhibitory concentration: 140 nM
Compound 4: middle estimate off by 1.1-fold (0.03 log units), on the high side; measured number inside the range.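

In this assay, the replacement of hydroxy by amino on a saturated chain carbon bound to a carbonyl carbon gives a 1.3-fold higher number from compound 2 to compound 4 (0.10 log units; within the scatter), so the two values cannot be told apart. The same replacement had also left the number within the scatter on the other core, and the two steps cannot be distinguished from each other: the same change on two cores in this assay, a 1.4-fold higher number (0.15 log units; within the scatter) from compound 1 to compound 3 and a 1.3-fold higher number (0.10 log units; within the scatter) from compound 2 to compound 4, 1.1-fold (0.05 log units) apart, within the scatter of two such steps. For these two pairs, in this one cell assay, the change therefore carries from one core to the other with the same result, a step too small to read as an effect, but this does not show that it would carry to any further core, nor does it show that the two groups are equivalent in any respect other than this read-out.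

The compounds shown leave open what happens when the hydroxymethyl or aminomethyl group gives way to something else on the same carbonyl, such as a dimethylamino group, a carboxylic acid or a longer chain. They also leave open whether the two cores would stay in step for such groups, where a larger step might be seen.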